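This account rests on a few compounds, and the source may have more. Where it says the series, first, only, none or still open, it means among the compounds named here.

In an ADME assay on microsomes from liver (Homo sapiens) for metabolic stability (on this read-out lower numbers stand for a shorter-lived compound and higher numbers for a longer-lived compound), compound 1 (`CC(C)C(Cc1ncc[nH]1)c1ccc(-c2ccc3cccc(F)c3c2)[nH]c1=O`) gives 0.106 h as the lower of the two numbers at hand. Compound 3 (`CC(C)[C@H](C[C@H]1CCNC1=O)c1ccc(-c2ccc3cccc(F)c3c2)[nH]c1=O`) gives 0.257 h and stands higher than compound 1, beyond the scatter of repeated measurements. Compound 2 (`CCn1ncc2c(F)cc(-c3ccc(C(CC)(CC)c4nnc(C)[nH]4)c(=O)[nH]3)cc21`) is reported as > 3 h and that is a limit of the assay, not a number.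

Compound 4 (`CC(C)C(c1ccc(-c2ccc3cccc(F)c3c2)[nH]c1=O)N1CCN/C1=N\C#N`) departs from compound 1 in one place (a group of 8 heavy atoms (4 carbon, 4 nitrogen; one five-membered non-aromatic ring with 2 hetero atoms) in place of a group of 6 heavy atoms (4 carbon, 2 nitrogen; one five-membered aromatic ring with 2 hetero atoms), on a saturated chain carbon bound to an aromatic carbon and a saturated chain carbon) on a saturated chain carbon bound to an aromatic carbon and a saturated chain carbon, where the (1H-imidazol-2-yl)methyl group gives way to a group with one five-membered non-aromatic ring with 2 hetero atoms. For the measured compounds named here, no two measured compounds differ in one place only, so no measured step speaks to this change directly. The nearest guide is compound 3 at 0.257 h and it suggests a modest rise in this assay rather than a fall. The estimated step of a 2.4-fold higher number from compound 1 to compound 4 (0.37 log units; beyond the scatter) is expected to lie a little beyond the scatter. Compound 4 is expected at 0.25 h with an estimated range from 0.08 h to 0.8 h for the coming measurement.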

Compound 4, half-life: 0.632 h
Beside the measured number, compound 4's estimate is 2.5-fold (0.40 log units) below it; the measured number falls inside the stated range.
By their numbers in this assay, from the lowest: compound 1; then compound 3; then compound 4. At a limit, above all of these: compound 2.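

Replacing the (1H-imidazol-2-yl)methyl group with the group holding a five-membered non-aromatic ring gives a 6.0-fold higher number from compound 1 to compound 4 (0.78 log units; beyond the scatter), on a saturated chain carbon bound to an aromatic carbon and a saturated chain carbon. For the compounds shown here, this pair is the first to differ in one place only, and it shows that in this assay the read-out responds to this change while the shared core stays the same. Nothing measured here accounts for the rise.

As far as these compounds go, whether the step belongs to the non-aromatic ring itself or to the nitrile it carries remains open. From the compounds shown here alone, it is also open how this assay would respond at this place to a simple amine or a carboxylic acid, as a single step cannot tell how far the trend extends to other groups.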